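Removing the side chain of compound 2: hydroxamate series

The compounds below may be only part of what the source reports. "The series", "measured", "known", "first", "only" and "open" are said of these compounds alone.

Compound 1 `O=C(NC1(C(=O)NO)CCS(=O)(=O)CC1)c1ccc(C#Cc2ccccc2)cc1` gives 3 in a physicochemical assay for lipophilicity; a lower number here means a more polar compound, a higher number a more lipophilic compound. Compound 2 `COCCNC(=O)C[C@H](NC(=O)c1ccc(C#Cc2ccccc2)cc1)C(=O)NO` gives 2. Compound 3 `O=C(NC1(C(=O)NO)CCNCC1)c1ccc(C#Cc2ccccc2)cc1` gives 3.

Compound 2 stands lowest of the three numbers; compound 1 and compound 3 each sit one whole unit higher, beyond the scatter. Compound 4 `O=C(CNC(=O)c1ccc(C#Cc2ccccc2)cc1)NO` has not yet been measured. It differs from compound 2 in one place: hydrogen in place of ((2-methoxyethyl)carbamoyl)methyl on a saturated chain carbon bound to an amide-type nitrogen and a carbonyl carbon. Among the measured compounds shown here, no step between measured compounds shows this exact change, so the expectation rests on the whole set: compound 1 and compound 3, both lacking such a chain, give the higher values. Compound 4 is therefore expected to move upward, with a step of a number 0.70 log units higher from compound 2 to compound 4 (beyond the scatter), beyond the scatter. Compound 4 is estimated at 2.7, within a range from 2 to 3.4.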

Compound 4, distribution coefficient: 3
The estimate for compound 4 lay 0.30 log units below the measured number; the measured number falls inside the stated range.
By their numbers in this assay, from the lowest: compound 2; then compounds 1, 3 and 4 (each within the scatter of the next).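

In this assay, among the compounds shown here, replacing the ((2-methoxyethyl)carbamoyl)methyl group with hydrogen on this saturated chain carbon gives a number 1.00 log units higher from compound 2 to compound 4 (beyond the scatter), a direct reading of a change at one place that the earlier compounds did not offer. Nothing given here bears on why the number moves. This single pair leaves open how the number would run with a methyl group, a carboxylic acid or an amine on this carbon. It also leaves open whether the methoxyethyl end or the carbamoyl part of the chain accounts for the step.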